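Trifluoromethyl in Place of Methyl on the Pyrazole Aryl

The source may report more compounds than this note shows. Statements on the series, on what has been measured and on what is new or still open speak of the compounds shown alone.

Three compounds share one core and differ only in the aryl on the sulfonyl sulfur: compound 1 `Cc1ccc(-c2nn(-c3ccccc3)cc2-c2nc3ccccc3n2S(=O)(=O)c2ccccc2)cc1`, compound 2 `Cc1ccc(-c2nn(-c3ccccc3)cc2-c2nc3ccccc3n2S(=O)(=O)c2cc(C)ccc2C)cc1` and compound 3 `Cc1ccc(-c2nn(-c3ccccc3)cc2-c2nc3ccccc3n2S(=O)(=O)c2ccc(Br)cc2)cc1`. In a functional assay on HeLa cells (Homo sapiens) for antiproliferative activity, read by MTT assay, with a stated time of 24 h (on this read-out lower numbers stand for stronger inhibition and higher numbers for weaker inhibition), compound 1 gives 820 nM, compound 2 gives 370 nM and compound 3 gives 2340 nM. Compound 2 stands lowest of the three, with a 2.2-fold lower number from compound 1 to compound 2 (0.35 log units; beyond the scatter) and a 6.3-fold higher number from compound 2 to compound 3 (0.80 log units; beyond the scatter). Compound 4 `Cc1ccc(C)c(S(=O)(=O)n2c(-c3cn(-c4ccccc4)nc3-c3ccc(C(F)(F)F)cc3)nc3ccccc32)c1` keeps the sulfonyl aryl of compound 2 and changes elsewhere: trifluoromethyl in place of methyl on an aromatic carbon. For the measured compounds named here, no measured step touches that position, so none bears directly on it, and nothing beyond the scatter is expected. Compound 4 is expected to give about 420 nM, between 150 nM and 1200 nM. That estimate means an expected 1.1-fold higher number from compound 2 to compound 4 (0.06 log units; within the scatter).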

Compound 4, half-maximal inhibitory concentration: 210 nM
Compound 4: middle estimate off by 2.0-fold (0.30 log units), on the high side, and the stated range covers the measured number.
By their numbers in this assay, from the lowest: compounds 4 and 2 (each within the scatter of the next); then compound 1; then compound 3.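

For the compounds shown here, the earlier compounds varied only the aryl on the sulfonyl sulfur, so compound 4 gives the first reading at the 4-methylphenyl group. In this assay, 4-(trifluoromethyl)phenyl in place of 4-methylphenyl gives a 1.8-fold lower number from compound 2 to compound 4 (0.25 log units; within the scatter), so this position accepts trifluoromethyl with no difference that can be told from methyl. No measurement shown here bears on this result. Open, as far as these compounds go, are an amine or a carboxylic acid at this position, and whether trifluoromethyl reads the same with the sulfonyl aryl of compound 1 or compound 3.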